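A Fluorine Moves Around the Ring

The source may hold more compounds than are shown below. What is called first, only, known or untested is meant among the compounds shown, and "the series" means these compounds.

Compound 1 `O=C(/C=C/c1ccc2c(c1)B(O)OC2)c1ccccc1` carries a plain phenyl on its carbonyl carbon. Among the compounds with values here, in a functional assay on SK-OV-3 cells (Homo sapiens) for cytotoxicity, read by MTT assay, with a stated time of 48 h (a lower number here means a stronger inhibitor, a higher number a weaker inhibitor), compound 1 gives 3400 nM, the lowest of the three numbers measured so far. Compound 2 `O=C(/C=C/c1ccc2c(c1)B(O)OC2)c1cccnc1`, with pyridin-3-yl in place of phenyl on that carbonyl carbon, gives 18500 nM; the step of a 5.4-fold higher number from compound 1 to compound 2 (0.74 log units; beyond the scatter) shows that this ring can shift the result well beyond the scatter. Compound 3 `O=C(/C=C/c1ccc2c(c1)B(O)OC2)c1ccccc1F`, with fluoro in place of hydrogen on an aromatic carbon, gives 3700 nM, and the step of a 1.1-fold higher number from compound 1 to compound 3 (0.04 log units; within the scatter) stays within the scatter.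

Compound 4 `O=C(/C=C/c1ccc2c(c1)B(O)OC2)c1cccc(F)c1` makes a closely related change: fluoro in place of hydrogen on an aromatic carbon. Within the data shown here, the only measured step that bears directly on it is the one to compound 3, a 1.1-fold higher number from compound 1 to compound 3 (0.04 log units; within the scatter), which was flat. A step in this assay of no more than the scatter is therefore expected, in either direction. Compound 4 is expected to give 3500 nM, with a range from 1700 nM to 7500 nM. The expected step of a 1.0-fold higher number from compound 1 to compound 4 (0.01 log units; within the scatter) is estimated to stay within the scatter.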

Compound 4, half-maximal inhibitory concentration: 4800 nM
Estimate against measurement, compound 4: 1.4-fold (0.14 log units) below; the range from low to high includes it.
By their numbers in this assay, from the lowest: compounds 1, 3 and 4 (each within the scatter of the next); then compound 2.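

Placed meta to a large group, fluoro also leaves this assay within the scatter, with a 1.4-fold higher number from compound 1 to compound 4 (0.15 log units; within the scatter), so a second site on this ring accepts the same small change without a clear shift. The two fluoro placements cannot be told apart, with a 1.3-fold higher number from compound 3 to compound 4 (0.11 log units; within the scatter), so for these two compounds the position of the fluoro makes no visible difference. Within the data shown here, the pyridin-3-yl ring remains the only change here that moves the number beyond the scatter, as a 3.9-fold lower number from compound 2 to compound 4 (0.59 log units; beyond the scatter) shows, and no measured evidence here explains why either ring behaves as it does.

On these data alone, whether a larger group at this site, such as trifluoromethyl, methoxy or an amine, would leave the number unchanged remains open. As far as these compounds go, it is also open whether a carboxylic acid on this ring would shift it as far as the pyridin-3-yl ring does.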